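The source may hold more compounds than are shown below. What is called first, only, known or untested is meant among the compounds shown, and "the series" means these compounds.

Working notes on the series. In a toxicity assay on HepG2 cells (Homo sapiens) for inhibition, read by CellTiter-Glo, with a stated time of 48 h (a lower number here means a stronger inhibitor, a higher number a weaker inhibitor), compound 1 `CCOc1ccc2nc(C(F)(F)F)cc(OCC(=O)Nc3cc(C)cc(C)c3)c2c1` gives > 100000 nM, which is a limit of the assay rather than a number. Among the compounds with values here, compound 3 `COc1ccc2nc(C)cc(NCC(=O)Nc3cc(C)cc(C)c3)c2c1` gives 6310 nM in this assay and is the only member read as a number. Compound 2 `COc1ccc2nc(C)cc(OCC(=O)NCc3cc(C)cc(C)c3)c2c1` gives > 100000 nM in this assay, again a limit and not a number. On the numbers shown, compound 2 therefore stands at the limit together with compound 1, while compound 3 alone carries a numerical reading; no step between two measured compounds can be written out, since no two of them differ in a single place. The next compound is compound 4 `COc1ccc2nc(C)cc(OCC(=O)Nc3cc(C)c(F)c(C)c3)c2c1`, which differs from compound 2 by 4-fluoro-3,5-dimethylphenyl in place of 3,5-dimethylbenzyl on an amide-type nitrogen. Compound 1 and compound 3 both carry their aromatic ring on the amide-type nitrogen, and they sit one at the limit and one at a number, so the change in compound 4 points in no clear direction. The expected step from compound 2 to compound 4 is a step that the limit leaves unreadable from compound 2 to compound 4, meaning nothing beyond the scatter, because the limit of > 100000 nM in this assay, at which 2 of the 3 values shown sit, holds 2 of the 3 values shown. Compound 4 is expected to give 120000 nM in this assay, within 30000 nM to 500000 nM, and most likely to be reported again only as a limit.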

Compound 4, half-maximal inhibitory concentration: > 100000 nM
Compound 4: a limit, no number; the forecaster's own chance of this, stated with the estimate: 70%; the middle value is on the limit's open side.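

Compound 2 and compound 4 both stand at a limit of the assay and not at a number, so no step from one to the other can be read: the limit of > 100000 nM in this assay, at which 3 of the 4 values shown sit.

The compounds shown leave open whether 4-fluoro-3,5-dimethylphenyl in place of 3,5-dimethylbenzyl on an amide-type nitrogen changes the reading at all.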